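The compounds below may be only part of what the source reports. "The series", "measured", "known", "first", "only" and "open" are said of these compounds alone.

Measured so far in an in vitro ADME assay on microsomes from liver (Mus musculus) for pharmacokinetics, read by LC-MS, with a stated time of 10 min, tested at 1 uM; a higher number here means faster removal of the compound, a lower number slower removal: compound 1 `COc1ccc(NC(=O)[C@H]2CN(C)C[C@@H]2c2ccc(/C=C/C(=O)Nc3ccccc3N)cc2)cc1` gives 54 mL/min/kg; compound 2 `Cc1cc(NC(=O)[C@H]2CN(C)C[C@@H]2c2ccc(/C=C/C(=O)Nc3ccccc3N)cc2)ccc1F` gives 62 mL/min/kg; compound 3 `Cc1cc(NC(=O)[C@H]2CN(C)C[C@@H]2c2ccc(/C=C/C(=O)Nc3ccccc3N)cc2)ccc1Cl` gives 65 mL/min/kg.

Compound 3 stands with the other two inside the scatter, as a 1.2-fold higher number from compound 1 to compound 3 (0.08 log units; within the scatter) and a 1.0-fold higher number from compound 2 to compound 3 (0.02 log units; within the scatter) show; the whole set is spread narrowly, with a 1.1-fold higher number from compound 1 to compound 2 (0.06 log units; within the scatter) also within scatter. Compound 4 `CN1C[C@H](C(=O)N2CCCCC2)[C@@H](c2ccc(/C=C/C(=O)Nc3ccccc3N)cc2)C1` differs from compound 3 as follows: piperidin-1-yl in place of (4-chloro-3-methylphenyl)amino on a carbonyl carbon. For the measured compounds named here, no measured step bears directly on this change; the three steps known alter only the substituents of the aryl group on the amide-type nitrogen, and each was small. On that basis compound 4 is expected to stay near the range of the measured set, with a 1.2-fold lower number from compound 3 to compound 4 (0.07 log units; within the scatter) estimated as a step not beyond the scatter. Compound 4 is therefore estimated at 55 mL/min/kg, in the range 28 mL/min/kg to 110 mL/min/kg.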

Compound 4, clearance: 42 mL/min/kg
For compound 4 the middle estimate is 1.3-fold (0.12 log units) above the measured one; the range from low to high includes it.
By their numbers in this assay, from the lowest: compounds 4, 1, 2 and 3 (each within the scatter of the next).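

Compound 4 shows that in this assay the change can reach beyond the substituents of the aryl group: the whole arylamino group on this carbonyl carbon gives way to piperidin-1-yl, an aromatic ring replaced by a non-aromatic one, with small steps (a 1.5-fold lower number from compound 3 to compound 4 (0.19 log units; within the scatter); a 1.5-fold lower number from compound 2 to compound 4 (0.17 log units; within the scatter); a 1.3-fold lower number from compound 1 to compound 4 (0.11 log units; within the scatter)). All three stay within the scatter, so this exchange shows no clear change in clearance. Nothing measured here explains these numbers.

Still open, as far as these compounds go, is whether an open-chain amine such as dimethylamino, or a morpholine ring, in this place would stay in the same range.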